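The source may hold more compounds than are shown below. What is called first, only, known or untested is meant among the compounds shown, and "the series" means these compounds.

In a functional assay on DU-145 cells (Homo sapiens) for cytotoxicity, read by ELISA, with a stated time of 4 days (a lower number here means a stronger inhibitor, a higher number a weaker inhibitor), compound 1 (`Cc1ccsc1-c1cc(-c2ccco2)cc(-c2ccc(Cl)cc2)n1`) gives 26700 nM and compound 2 (`Cc1ccsc1-c1cc(-c2ccc(Cl)o2)cc(-c2cccc(Cl)c2)n1`) gives 20500 nM and these two values lie within the scatter of each other. Compound 3 (`Cc1ccsc1-c1cc(-c2ccc(Cl)o2)cc(-c2ccc(Cl)cc2)n1`) has 4-chlorophenyl in place of the 3-chlorophenyl of compound 2 on an aromatic carbon, next to the ring nitrogen (4-chlorophenyl in place of 3-chlorophenyl on an aromatic carbon). Within the data shown here, no measured pair shows this change alone, and in this assay no step beyond the scatter is expected in either direction. The estimated step is a 1.0-fold lower number from compound 2 to compound 3 (0.01 log units; within the scatter) and it is expected to stay within the scatter. Compound 3 is expected at 20000 nM (estimated range 9000 nM to 40000 nM).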

Compound 3, half-maximal inhibitory concentration: 21900 nM
For compound 3 the middle estimate is 1.1-fold (0.04 log units) below the measured one; the range from low to high includes it.
By their numbers in this assay, from the lowest: compounds 2, 3 and 1 (each within the scatter of the next).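

In this assay, 4-chlorophenyl in place of 3-chlorophenyl at this position gives a 1.1-fold higher number from compound 2 to compound 3 (0.03 log units; within the scatter), so the two chlorophenyl groups are not told apart here. Chloro in place of hydrogen on the furan ring, seen with the 4-chlorophenyl group kept, gives a 1.2-fold lower number from compound 1 to compound 3 (0.09 log units; within the scatter), and this change also leaves the number within the scatter. Nothing available bears on why either step is so small.
Still open, as far as these compounds go, is whether an amine or a carboxylic acid on the phenyl ring at this position would move the number beyond the scatter.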